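The source may hold more compounds than are shown below. What is called first, only, known or untested is meant among the compounds shown, and "the series" means these compounds.

Compound 3 `CO/N=C(/COc1ccc2c(=O)cc(-c3ccccc3)oc2c1)c1ccccc1` gives 2000000 nM in a functional assay on SK-HEP1 cells (Homo sapiens) for antiproliferative activity; on this read-out higher numbers stand for weaker inhibition of growth and lower numbers for stronger inhibition of growth. It stands level with compound 1 `CO/N=C(\C)COc1ccc2c(=O)cc(-c3ccccc3)oc2c1`, which gives 2000000 nM, and the two together hold the lowest numbers of the three, while compound 2 `O=c1cc(-c2ccccc2)oc2cc(OC/C(=N/O)c3ccc(F)cc3)ccc12`, with 2300000 nM, lies within the scatter of both. Within the data shown here, the only single-point step known here, no change at the digits printed from compound 1 to compound 3 (within the scatter), shows no movement. Compound 4 `CO/N=C(/COc1ccc2c(=O)cc(-c3ccccc3)oc2c1)c1ccc(F)cc1` differs from compound 3 by fluoro in place of hydrogen on an aromatic carbon. Among the measured compounds shown here, no measured step isolates this change; compound 2 carries a 4-fluorophenyl with a free oxime and gives a number indistinguishable from compound 3. Compound 4 is therefore expected to show no change at the digits printed from compound 3 to compound 4 (within the scatter), no change beyond the scatter. Compound 4 is estimated at 2000000 nM, between 1000000 nM and 4000000 nM.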

Compound 4, concentration for 50% growth inhibition: 3300000 nM
Compound 4: the middle estimate sits 1.7-fold (0.22 log units) below what was measured, within the range that was stated.
By their numbers in this assay, from the lowest: compounds 1, 3, 2 and 4 (each within the scatter of the next).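

In this assay fluoro in place of hydrogen on the aromatic carbon para to a large group gives a 1.7-fold higher number from compound 3 to compound 4 (0.22 log units; within the scatter) and so this position now has a step of its own, one that stays within the scatter. Methyl in place of hydrogen on an oxygen gives a 1.4-fold higher number from compound 2 to compound 4 (0.16 log units; within the scatter) and 4-fluorophenyl in place of methyl gives a 1.7-fold higher number from compound 1 to compound 4 (0.22 log units; within the scatter) and neither step separates the compounds on this read-out. No measurement given here bears on these results. As far as these compounds go, whether an amine or a carboxylic acid at this position, or a longer chain in place of the 4-fluorophenyl, would move the number beyond the scatter stays open.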